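The source may report more compounds than this note shows. Statements on the series, on what has been measured and on what is new or still open speak of the compounds shown alone.

Working notes on the series, read-out an ADME assay on HepG2 2.2.15 cells (Homo sapiens) for cytotoxicity; on this read-out lower numbers stand for higher toxicity in this test and higher numbers for lower toxicity in this test. Going by the values given here, on the shared core, compound 1 (`CC(=O)NCC(=O)OCCc1c(-c2ccccc2Cl)c2cc(Cl)ccc2[nH]c1=O`) gives 110000 nM in this assay, and compound 2 (`O=C(OCCc1c(-c2ccccc2Cl)c2cc(Cl)ccc2[nH]c1=O)c1ccccc1`) gives 43000 nM, the lower of the two numbers so far. Among the compounds with values here, the only measured step is a 2.6-fold lower number from compound 1 to compound 2 (0.41 log units; beyond the scatter). It is modest but beyond the usual scatter, and it comes with phenyl in place of acetamidomethyl on a carbonyl carbon.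

The next structure is compound 3 (`O=C(OCCc1c(-c2ccccc2Cl)c2cc(Cl)ccc2[nH]c1=O)c1ccco1`), which has furan-2-yl in place of phenyl on a carbonyl carbon. Within the data shown here, no measured pair exchanges one aromatic ring for another, so the evidence here is indirect. Compound 3 keeps an aromatic ring at the place where compound 1 and compound 2 differ, and the modest size of a 2.6-fold lower number from compound 1 to compound 2 (0.41 log units; beyond the scatter) serves as a rough upper guide for this smaller change. The expected shift is a 1.2-fold higher number from compound 2 to compound 3 (0.07 log units; within the scatter), which is not expected to leave the scatter, and its direction is uncertain. For compound 3 the estimated value is 50000 nM, with an expected range of 25000 nM to 100000 nM.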

Compound 3, half-maximal cytotoxic concentration: 98000 nM
Beside the measured number, compound 3's estimate is 2.0-fold (0.29 log units) below it, and the stated range covers the measured number.
By their numbers in this assay, from the lowest: compound 2; then compounds 3 and 1 (each within the scatter of the next).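

In this assay, one aromatic ring cannot simply be swapped for another on this carbonyl carbon: furan-2-yl in place of phenyl gives a 2.3-fold higher number from compound 2 to compound 3 (0.36 log units; beyond the scatter) and so moves the number by a modest step beyond the scatter. Furan-2-yl in place of acetamidomethyl gives a 1.1-fold lower number from compound 1 to compound 3 (0.05 log units; within the scatter) and stays within the scatter, so the presence of an aromatic ring at this place does not by itself go with the lower number, and among the three compounds only phenyl, in compound 2, stands apart from the other two. Nothing at hand bears on what lies behind the gap between phenyl and furan-2-yl.

As far as these compounds go, whether the gap follows the smaller ring or the ring oxygen stays open, and a thiophen-2-yl or pyridin-3-yl group at this place would help to separate the two. From the compounds shown here alone, how an amine, a carboxylic acid or a longer chain on this carbonyl carbon would read in this assay also remains open.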